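A Chlorophenyl Swap at the Edge of Measurement

The source may hold more compounds than are shown below. What is called first, only, known or untested is meant among the compounds shown, and "the series" means these compounds.

In an ADME assay on HEK293 cells (Homo sapiens) for inhibition, read by MTT assay, with a stated time of 48 h (on this read-out higher numbers stand for weaker inhibition and lower numbers for stronger inhibition), compound 1 (`c1ccc(Sc2c(-c3cccc4ccccc34)nc3ccccn23)cc1`) gives > 100000 nM as a limit of the assay and not a number. Compound 2 (`C(=C/c1nc2ccccn2c1Sc1ccccc1)\c1ccccc1`) gives > 100000 nM as a limit too. Compound 2 therefore has no exact value, and one other compound shares that position (the limit of > 100000 nM in this assay, at which 2 of the 3 values shown sit). Compound 3 (`Clc1ccc(Sc2c(-c3cccs3)nc3ccccn23)cc1`) gives an exact number of 93000 nM and so also shows only weak inhibition.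

Compound 4 (`Clc1ccc(-c2nc3ccccn3c2Sc2ccccc2)cc1`) has not yet been measured. It differs from compound 2 by a single change, 4-chlorophenyl in place of 2-phenylethenyl on an aromatic carbon. Among the measured compounds shown here, no two measured compounds show the effect of this change directly, so the only guide is that all three sit in the same weak range. The step expected in this assay is therefore none beyond the scatter (a number no higher from compound 2 to compound 4 (the limit leaves the size open)). Compound 4 is estimated at 100000 nM with an expected range from 45000 nM to 220000 nM and may well return only a limit.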

Compound 4, half-maximal inhibitory concentration: > 100000 nM
Compound 4: a limit, no number; the forecaster's own chance of this, stated with the estimate: 60%; the middle value sits exactly at the limit.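

Compound 4 gives > 100000 nM, a limit of the assay and not a number. Compound 2 is also a limit, so no step can be read between compound 2 and compound 4. On these data alone, whether 4-chlorophenyl in place of 2-phenylethenyl changes inhibition at all, and by how much, stays open.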